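A few compounds are considered here, and "the series" means these few. Any claim that something is new, unique, unknown or untested is made for them only; others in the source may bear on it.

Measured so far in an ADME assay on microsomes from liver (Homo sapiens) for metabolic stability, read by LC-MS, with a stated time of 10 min; on this read-out higher numbers stand for a more stable compound and lower numbers for a less stable compound:
compound 1 `CCN1CCN(c2cccc3c2C[C@H](CN(C)[C@H]2CCCc4cccnc42)NC3)CC1` gives 0%
compound 2 `CN1CCN(c2cccc3c2C[C@H](CN(C)[C@H]2CCCc4cccnc42)N(C)C3)CC1` gives 83.3%
compound 3 `CN(C[C@H]1Cc2c(cccc2N2CCN3CCC[C@@H]3C2)CN1)[C@H]1CCCc2cccnc21` gives 52.2%

Compound 3 sits second highest of the three numbers in this assay; compound 2 lies above it by a margin beyond the scatter, and compound 1 lies below it by a larger margin, also beyond the scatter.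

The step to compound 4 `CN1CCN(c2cccc3c2C[C@H](CN(C)[C@H]2CCCc4cccnc42)NC3)CC1` is a group of 7 heavy atoms (5 carbon, 2 nitrogen; one six-membered non-aromatic ring with 2 hetero atoms) in place of a group of 9 heavy atoms (7 carbon, 2 nitrogen; one five-membered non-aromatic ring with 1 hetero atom, one six-membered non-aromatic ring with 2 hetero atoms), on an aromatic carbon. Going by the values given here, only one measured step bears on it: a number 52.2 percentage points higher from compound 1 to compound 3 (beyond the scatter), which introduced the same group that now leaves, on the same aromatic carbon. Going from compound 3 to compound 4 runs that change in reverse, with the 4-methylpiperazin-1-yl entering in place of the group that left in compound 1. A drop of comparable size is therefore expected in this assay, so that compound 4 is expected to land closer to compound 1 than to compound 2, a step of a number 40.2 percentage points lower from compound 3 to compound 4 (beyond the scatter). Compound 4 is expected to give 12%, with a range from 0% to 35%.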

Compound 4, percent of the compound remaining: 75.8%
Estimate against measurement, compound 4: 63.8 percentage points below; the whole stated range lies below it.
By their numbers in this assay, from the lowest: compound 1; then compound 3; then compounds 4 and 2 (each within the scatter of the next).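

In this assay, the large change at this aromatic carbon is a difference of a single carbon on the piperazine. Hydrogen in place of methyl on the saturated chain carbon gives a number 75.8 percentage points higher from compound 1 to compound 4 (beyond the scatter), and 4-methylpiperazin-1-yl also outdoes the fused two-ring group, with a number 23.6 percentage points higher from compound 3 to compound 4 (beyond the scatter). On the core, hydrogen in place of methyl on the ring amine nitrogen gives a number 7.5 percentage points lower from compound 2 to compound 4 (within the scatter), so that change cannot be told from the scatter in this assay. No evidence at hand explains either step at this position.

Open, going by these compounds, is how a piperazine carrying hydrogen or a longer chain such as propyl in place of the methyl would read. Also open, on these data alone, is whether the ethyl group of compound 1 would read the same with a methyl on the ring amine nitrogen of the core.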